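A few compounds are considered here, and "the series" means these few. Any claim that something is new, unique, unknown or untested is made for them only; others in the source may bear on it.

In a functional assay on NALM-6 cells (Homo sapiens) for cytotoxicity, with a stated time of 72 h (a higher number here means that more compound is needed for the effect, a lower number that less compound is needed), compound 1 `C=C[C@@](C)(/C=C/c1ccc(OCc2ccccc2)cc1)CCC=C(C)C` gives > 43400 nM, which is a limit and not a number. Compound 2 `C=C[C@@](C)(/C=C/c1ccc(Nc2ccc(F)c(F)c2)cc1)CCC=C(C)C` gives > 43400 nM, which is also only a limit. Compound 3 `C=C[C@@](C)(/C=C/c1ccc(Nc2ccc(Cl)c(Cl)c2)cc1)CCC=C(C)C` gives > 43400 nM, again a limit, so it has no number of its own. All three compounds therefore stand at the limit of > 43400 nM in this assay, at which 3 of the 3 values shown sit.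

The next compound, compound 4 `C=C[C@@](C)(/C=C/c1ccc(-c2ccc(Cl)cc2)cc1)CCC=C(C)C`, has not yet been measured. In it, 4-chlorophenyl takes the place of (3,4-dichlorophenyl)amino on an aromatic carbon, para to a large group: 4-chlorophenyl in place of (3,4-dichlorophenyl)amino on an aromatic carbon.

Among the compounds with values here, three measured steps bear on this change. Within the data shown here, the first is a step that the two limits leave unreadable from compound 1 to compound 3, the second is a step that the two limits leave unreadable from compound 2 to compound 3, and the third is a step that the two limits leave unreadable from compound 1 to compound 2. None of them has a readable size, so they offer no measured size or direction for the new replacement. Compound 4 is therefore expected to show no step beyond the scatter in this assay, and a report of only a limit is the likeliest outcome. The estimated step is a step that the limit leaves unreadable from compound 3 to compound 4. For compound 4 the expected value is 45000 nM. The estimated range for compound 4 runs from 15000 nM to 90000 nM.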

Compound 4, half-maximal effective concentration: > 43400 nM
Compound 4 ended at the assay's limit; the forecaster's own chance of this, stated with the estimate: 80%; the middle value lies beyond the limit too.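

In this assay compound 4 gives > 43400 nM, which is again a limit and not a number, so the steps from compound 1, compound 2 and compound 3 to compound 4 cannot be read. All four compounds stand together: the limit of > 43400 nM in this assay, at which 4 of the 4 values shown sit.

The compounds shown leave open which group on the shared core, if any, would give a measurable value in this assay.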